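This account rests on a few compounds, and the source may have more. Where it says the series, first, only, none or still open, it means among the compounds named here.

Going by the values given here, compound 2 `CCOc1ccc(NC(=O)c2cccc(/C=C3\CC(=O)N(Cc4ccccc4)C3=O)c2)cc1` gives 41700 nM in an ADME assay on HCT-116 cells (Homo sapiens) for cytotoxicity, read by MTT assay, with a stated time of 72 h (on this read-out higher numbers stand for weaker inhibition and lower numbers for stronger inhibition), and holds the only number in the set. Compound 1 `O=C(Nc1cccc(F)c1)c1cccc(/C=C2\CC(=O)N(c3ccccc3)C2=O)c1` stands at the limit of > 100000 nM in this assay, at which 1 of the 2 values shown sits, a limit of the assay rather than a number. Compound 3 `CCOc1ccc(NC(=O)c2cccc(/C=C3\CC(=O)N(c4ccccc4)C3=O)c2)cc1` carries phenyl in place of benzyl on an amide-type nitrogen in a ring, the shift being phenyl in place of benzyl on an amide-type nitrogen in a ring. Among the compounds with values here, no measured step covers this change; the expectation leans on compound 1, which also bears phenyl on that nitrogen and reads > 100000 nM as a limit. Compound 3 is expected to come out weaker in this assay, by a step of a 2.2-fold higher number from compound 2 to compound 3 (0.33 log units; beyond the scatter) beyond the scatter, and may itself reach the limit. The estimate for compound 3 is 90000 nM, within 30000 nM to 300000 nM.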

Compound 3, half-maximal inhibitory concentration: 84800 nM
Estimate against measurement, compound 3: 1.1-fold (0.03 log units) above; the measured number falls inside the stated range.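

In this assay, the change on an amide-type nitrogen in a ring now has a size: a 2.0-fold higher number from compound 2 to compound 3 (0.31 log units; beyond the scatter), a modest step that favours benzyl over phenyl, seen in this one pair only. For 4-ethoxyphenyl in place of 3-fluorophenyl on an amide-type nitrogen, the reading is an at least 1.1-fold lower number from compound 1 to compound 3 (0.07 log units; that floor lies within the scatter), which fixes no direction. Compound 1 gives a limit and not a number: the limit of > 100000 nM in this assay, at which 1 of the 3 values shown sits.

Open, from the compounds shown here alone, is whether a longer chain such as phenethyl, or an aminoethyl chain, on the ring nitrogen moves the number further. Also open, going by these compounds, is whether benzyl keeps its edge with 3-fluorophenyl on the amide.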